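Solubility notes, from compound 3 to compound 4

This account rests on a few compounds, and the source may have more. Where it says the series, first, only, none or still open, it means among the compounds named here.

Measured so far:
Compound 1 `CNC(=O)c1cc(C(=O)N[C@H]2[C@@H]3C[C@H](O)C[C@@H]32)n([C@@H](C)c2cccc(Cl)c2)n1` gives 327 ug/mL in a physicochemical assay for solubility, read by HPLC, in simulated intestinal fluid, with a stated time of 16 h, at pH 6.5; a lower number here means a less soluble compound, a higher number a more soluble compound.
Compound 2 `CNC(=O)c1cc(C(=O)N[C@H]2CC[C@H](O)CC2)c([C@@H](C)c2cccc(C)c2)o1` gives > 1000 ug/mL in this assay, a limit of the assay and not a number.
Compound 3 `CNC(=O)c1cc(C(=O)N[C@H]2CC[C@H](O)CC2)c([C@@H](C)c2ccccc2Cl)o1` gives > 1000 ug/mL in this assay, again a limit and not a number.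

Compound 3 therefore stands at the top of what this assay can report, sharing that position with compound 2; this is the limit of > 1000 ug/mL in this assay, at which 2 of the 3 values shown sit. Among the measured compounds shown here, the one step that differs in a single place, a step that the two limits leave unreadable from compound 2 to compound 3, runs between two limits and its size cannot be read. For the measured compounds named here, compound 1 is the only compound with a numeric value, and no single-place step links it to compound 3.

Compound 4 `CNC(=O)c1cc(C(=O)N[C@H]2CC[C@H](O)CC2)c([C@@H](C)c2cccc(OC)c2)o1`, not yet measured, differs from compound 3 by 3-methoxyphenyl in place of 2-chlorophenyl on a saturated chain carbon bound to an aromatic carbon and a saturated chain carbon.

Going by the values given here, no measured step in this assay bears directly on this exchange, so no direction can be set from the series itself. With compound 3 sitting at the limit, the expectation is that compound 4 also reaches the limit in this assay and that no numeric readout results. Compound 4 is estimated at 1000 ug/mL, within 400 ug/mL to 1500 ug/mL. The step this implies, a number no higher from compound 3 to compound 4 (the limit leaves the size open), is expected to lie within the scatter.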

Compound 4, solubility: 868 ug/mL
Compound 4: the middle estimate sits 1.2-fold (0.06 log units) above what was measured; measured number inside the range.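

In this assay, among the compounds shown here, compound 4 gives 868 ug/mL, the only number among the compounds that share its core. A substituted phenyl on a saturated chain carbon bound to an aromatic carbon and a saturated chain carbon therefore need not reach the limit of the read-out. The exchange of 2-chlorophenyl for 3-methoxyphenyl reads as an at least 1.1-fold lower number from compound 3 to compound 4 (0.06 log units; that floor lies within the scatter), and methoxy in place of methyl on an aromatic carbon reads as an at least 1.1-fold lower number from compound 2 to compound 4 (0.06 log units; that floor lies within the scatter). Both steps are only floors, and neither shows a change beyond the scatter, because compounds 2 and 3 sit at a limit: the limit of > 1000 ug/mL in this assay, at which 2 of the 4 values shown sit.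

As far as these compounds go, how far compounds 2 and 3 stand from compound 4 remains unknown, the step between compounds 2 and 3 cannot be read, and compound 1 differs from these compounds in more than one place, so it offers no comparison. Also open, from the compounds shown here alone, is how the read-out in this assay responds when the phenyl group at this position carries a carboxylic acid, an amine or a longer alkyl chain.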